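A few compounds are considered here, and "the series" means these few. Any claim that something is new, unique, unknown or untested is made for them only; others in the source may bear on it.

Compound 1 `Cc1ccccc1-n1nncc1CN1C(=O)C2(C(C#N)=C(N)Oc3c2c2nc4ccccc4nc2c2ccccc32)c2ccccc21` — in an ADME assay on HUVEC cells (Homo sapiens) for antiproliferative activity, read by MTT assay, with a stated time of 48 h (a higher number here means a weaker inhibitor, a lower number a stronger inhibitor), compound 1 reaches only the limit > 50000 nM.
Compound 2 `COc1ccc(-n2nncc2CN2C(=O)C3(C(C#N)=C(N)Oc4c3c3nc5ccccc5nc3c3ccccc43)c3ccccc32)cc1` — in this assay compound 2 likewise reaches only the limit > 50000 nM.

Among the measured compounds shown here, compound 2 therefore stands at the limit of this assay, not at a number, and the same holds for the one other value shown (the limit of > 50000 nM in this assay, at which 2 of the 2 values shown sit). For the measured compounds named here, the single measured step, the step that the two limits leave unreadable from compound 1 to compound 2, is left unreadable by the two limits, so it gives no direction or size to carry forward. Compound 3 `CCOc1ccc(-n2nncc2CN2C(=O)C3(C(C#N)=C(N)Oc4c3c3nc5ccccc5nc3c3ccccc43)c3ccccc32)cc1` differs from compound 2 by methyl in place of hydrogen on a saturated chain carbon bound to an oxygen on an aromatic ring. Going by the values given here, no measured step bears on this change, and with both neighbours at the limit, compound 3 is expected to remain there as well, with an expected step that the limit leaves unreadable from compound 2 to compound 3 in this assay. Compound 3 is estimated at 100000 nM, within 40000 nM to 400000 nM.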

Compound 3, half-maximal inhibitory concentration: > 50000 nM
Compound 3: only a limit was reported (the forecaster's own chance of this, stated with the estimate: 85%); the middle value does not contradict the limit.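

Compound 1, compound 2 and compound 3 all stand at a limit in this assay, not at a number, so no step among them can be read: the limit of > 50000 nM in this assay, at which 3 of the 3 values shown sit.

The compounds shown leave open how 2-methylphenyl, 4-methoxyphenyl and 4-ethoxyphenyl compare, and where the actual half-maximal inhibitory concentration of each compound lies.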